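Adding a second chloro to compound 3

The source may hold more compounds than are shown below. What is called first, only, known or untested is meant among the compounds shown, and "the series" means these compounds.

In a physicochemical assay for solubility, in phosphate buffer, with a stated time of 18 h, at pH 7.4 (a higher number here means a more soluble compound, a lower number a less soluble compound), compound 3 `Nc1nc(-c2ccccc2)nn1-c1ncnc2cc(Cl)ccc12` gives 300 nM and stands lowest of the three measured compounds, with compound 1 `Nc1nc(-c2ccccc2)nn1-c1ncnc2ccccc12` at 1000 nM and compound 2 `Nc1nc(-c2ccccn2)nn1-c1ncnc2ccccc12` at 9000 nM on the same scale. Compound 4 `Nc1nc(-c2ccc(Cl)cc2)nn1-c1ncnc2cc(Cl)ccc12` differs from compound 3 by chloro in place of hydrogen on an aromatic carbon in one place: chloro in place of hydrogen on an aromatic carbon, turning phenyl to 4-chlorophenyl. The closest guide is a 3.3-fold lower number from compound 1 to compound 3 (0.52 log units; beyond the scatter) for a chloro added to the shared core, not to the phenyl. The step of a 9.0-fold higher number from compound 1 to compound 2 (0.95 log units; beyond the scatter) for pyridin-2-yl in place of phenyl alters the same ring, but it is a different kind of change and guides less. A lower number is therefore expected in this assay with a 3.3-fold lower number from compound 3 to compound 4 (0.52 log units; beyond the scatter) as the estimated step, though a single precedent elsewhere on the molecule leaves this uncertain. The expected value for compound 4 is 90 nM within a range from 30 nM to 300 nM as estimated.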

Compound 4, solubility: 5000 nM
Compound 4: middle estimate off by 56-fold (1.74 log units), on the low side; the whole stated range lies below it.
By their numbers in this assay, from the lowest: compound 3; then compound 1; then compounds 4 and 2 (each within the scatter of the next).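

In this assay chloro in place of hydrogen on the phenyl gives a 17-fold higher number from compound 3 to compound 4 (1.22 log units; beyond the scatter) while the same swap on the shared core gave a 3.3-fold lower number from compound 1 to compound 3 (0.52 log units; beyond the scatter) in the earlier step. Across these two steps, the direction of one small change therefore differs with where it is made. No measurement here explains this reversal.

As far as these compounds go, whether the higher number needs the chloro already on the core remains open. So does whether a different group on the phenyl at that place, such as an amine or a carboxylic acid, would move the number the same way.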